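This account rests on a few compounds, and the source may have more. Where it says the series, first, only, none or still open, it means among the compounds named here.

Compound 1, `CCOC(=O)N1CCC(=NNC(=O)c2ccc(C)cc2)CC1`: in a functional assay for inhibition, read by spectrophotometry, with a stated time of 120 min (a higher number here means a weaker inhibitor, a lower number a stronger inhibitor), compound 1 gives 52500 nM.
Compound 2, `COc1ccc(C(=O)NN=C2CC(c3ccccc3)NC(c3ccccc3)C2)cc1`: in this assay compound 2 gives 34500 nM.

Among the measured compounds shown here, only these two compounds have numbers so far, and they share no common step, so nothing can be said about how any single structural change has shifted the read-out. Compound 2 and compound 1 give numbers that lie within the usual scatter of each other, so neither can be called the stronger inhibitor on this evidence.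

Compound 3, `O=C(NN=C1CC(c2ccccc2)NC(c2ccccc2)C1)c1ccc([N+](=O)[O-])cc1`, is built on the core of compound 2 and differs from it in one place: nitro in place of methoxy on an aromatic carbon. For the measured compounds named here, no measured pair shows what a swap of this kind does, so the expectation rests on compound 2 alone. The step expected here, a 1.2-fold lower number from compound 2 to compound 3 (0.06 log units; within the scatter), is none beyond the scatter. Compound 3 is therefore estimated to give about 30000 nM, with a range from 10000 nM to 90000 nM.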

Compound 3, half-maximal inhibitory concentration: 45200 nM
The estimate for compound 3 lay 1.5-fold (0.18 log units) below the measured number, and the stated range covers the measured number.
By their numbers in this assay, from the lowest: compounds 2, 3 and 1 (each within the scatter of the next).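

Among the compounds shown here, the swap from 4-methoxyphenyl to 4-nitrophenyl is the first change made in one place only, and in this assay it amounts to a 1.3-fold higher number from compound 2 to compound 3 (0.12 log units; within the scatter) on the shared core. At this position, on an aromatic carbon para to a large group, methoxy and nitro therefore cannot be told apart, even though they share no atoms beyond oxygen. Nothing measured here speaks to why the two groups read alike.

Two groups cannot show whether this position responds to any change at all, and an amine, a carboxylic acid or a longer chain such as butoxy in the same place might still move the number beyond the scatter. As far as these compounds go, whether a change elsewhere on the shared core would do more also remains open.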